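Swapping a Benzyl Group on a Receptor Binder

The source may report more compounds than this note shows. Statements on the series, on what has been measured and on what is new or still open speak of the compounds shown alone.

Compound 1 `CCN(Cc1ccccc1)c1cc(C)nc(N(CC)c2ccc(C(C)C)cc2Br)n1` was tested in an assay on isolated protein for binding affinity to corticotropin-releasing factor receptor 1 (Homo sapiens) (a lower number here means a stronger inhibitor, a higher number a weaker inhibitor), where compound 1 gives 17 nM. Compound 3 `CCN(c1nc(C)cc(C)n1)c1c(Br)cc(C(C)C)cc1OC` gives 26 nM, and compound 2 `CCN(c1nc(C)cc(C)n1)c1ccc(OC)cc1SC` gives 60 nM. Compound 1 has the lowest of the three numbers; its gap to compound 3 lies within the usual scatter, while its gap to compound 2 lies beyond it. Compound 4 `CCCN(c1cc(C)nc(N(CC)c2ccc(C(C)C)cc2Br)n1)C1CC1` has not yet been measured. It differs from compound 1 in one place: cyclopropyl(propyl)amino in place of benzyl(ethyl)amino on an aromatic carbon. Within the data shown here, no measured pair shows this change, so its effect cannot be read from the data. The step of a 1.1-fold lower number from compound 1 to compound 4 (0.05 log units; within the scatter) is expected to stay within the scatter, with no clear direction. Compound 4 is therefore estimated at 15 nM, within a range from 5 nM to 50 nM.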

Compound 4, inhibition constant: 5 nM
Beside the measured number, compound 4's estimate is 3.0-fold (0.48 log units) above it; measured number inside the range.
By their numbers in this assay, from the lowest: compound 4; then compounds 1 and 3 (each within the scatter of the next); then compound 2.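

Cyclopropyl(propyl)amino in place of benzyl(ethyl)amino gives a 3.4-fold lower number from compound 1 to compound 4 (0.53 log units; beyond the scatter) in this assay. This position therefore does not need the six-membered aromatic ring of the benzyl group: a group with fewer heavy atoms and a three-membered non-aromatic ring gives the lower number. Nothing measured here explains this step. From the compounds shown here alone, compound 4 changes the ring and the chain together, so the share of each stays open. A dipropylamino or cyclopropyl(ethyl)amino group at this position would separate the two.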